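Which aryl group, and what it does to growth inhibition

The source may hold more compounds than are shown below. What is called first, only, known or untested is meant among the compounds shown, and "the series" means these compounds.

Of the compounds shown here, three have been measured in a functional assay on DU-145 cells (Homo sapiens) for inhibition, read by trypan blue exclusion, with a stated time of 96 h; on this read-out lower numbers stand for stronger inhibition of growth and higher numbers for weaker inhibition of growth. Compound 1 `CN(C)c1ccc(/C=C(/SCc2ccc(F)cc2)C(=O)c2ccc(Br)cc2)cc1` gives 50000 nM. Compound 2 `CSc1ccc(/C=C(\C(=O)c2ccc(Br)cc2)S(=O)(=O)c2ccc(C)cc2)cc1` gives 1000 nM, and compound 3 `COc1ccccc1/C=C(\C(=O)c1ccc(Br)cc1)S(=O)(=O)c1ccc(C)cc1` gives 1000 nM. Compound 3 therefore stands level with compound 2, the two sharing the lowest number, while compound 1 sits well apart from both. Within the data shown here, the one step that compares like with like, no change at the digits printed from compound 2 to compound 3 (within the scatter), shows that exchanging one aryl group for another on the shared core left the number where it was. The new compound 4 `Cc1ccc(S(=O)(=O)/C(=C/c2ccc(N(C)C)cc2)C(=O)c2ccc(Br)cc2)cc1` differs from compound 3 by the change (4-(dimethylamino)phenyl in place of 2-methoxyphenyl on a double-bonded chain carbon bound to a double-bonded chain carbon). This again exchanges the aryl group at the same place, so the nearest guide is the step from compound 2 to compound 3, which showed no change. Compound 1 carries the same 4-(dimethylamino)phenyl and gives a much higher number, but it differs from compound 4 in more than one place, so it is a weaker guide. For compound 4 the expected outcome is a modest step, a 2.0-fold higher number from compound 3 to compound 4 (0.30 log units; within the scatter), toward a weaker value. Compound 4 is therefore estimated at 2000 nM, within 500 nM to 20000 nM.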

Compound 4, concentration for 50% growth inhibition: 50000 nM
Estimate against measurement, compound 4: 25-fold (1.40 log units) below; the whole stated range lies below it.
By their numbers in this assay, from the lowest: compounds 2 and 3 (each within the scatter of the next); then compounds 1 and 4 (each within the scatter of the next).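

Exchanging 2-methoxyphenyl for 4-(dimethylamino)phenyl on a double-bonded chain carbon bound to a double-bonded chain carbon (in this assay, a 50-fold higher number from compound 3 to compound 4 (1.70 log units; beyond the scatter)) shows that the aryl group at this place can matter, which the earlier pair of compounds could not show. Changing only methylsulfanyl to dimethylamino on an aromatic carbon gives a step of the same printed size (a 50-fold higher number from compound 2 to compound 4 (1.70 log units; beyond the scatter)), so among compounds 2, 3 and 4 on the shared core, the dimethylamino compound stands apart. With 4-(dimethylamino)phenyl kept, (4-methylphenyl)sulfonyl in place of (4-fluorobenzyl)sulfanyl leaves the number where it was (no change at the digits printed from compound 1 to compound 4 (within the scatter)).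

Nothing measured here bears on the reason for these large steps. From the compounds shown here alone, whether a plain amine or a carboxylic acid in place of dimethylamino on an aromatic carbon would read like compound 2 or like compound 4 stays open.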